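The source may report more compounds than this note shows. Statements on the series, on what has been measured and on what is new or still open speak of the compounds shown alone.

The measured compounds:
compound 1 `COc1ccc(-c2nnc(SCCCN3CCN(c4nc5ccccc5o4)CC3)o2)cc1`: 66100 nM
compound 2 `Cc1ccc(-c2nnc(SCCCN3CCN(c4nc5ccccc5o4)CC3)o2)cc1`: 154000 nM
compound 3 `CC(C)(C)Oc1ccc(-c2nnc(SCCCN3CCN(c4nc5ccccc5o4)CC3)o2)cc1`: 121000 nM

All three share one core and differ only in the group on the outer aromatic ring. In a functional assay on HepG2 cells (Homo sapiens) for inhibition, read by MTT assay, with a stated time of 72 h (a lower number here means a stronger inhibitor, a higher number a weaker inhibitor), compound 1 gives the lowest of the three numbers; compound 3 stands nearest to it and compound 2 furthest. Within the data shown here, only one step separates compounds by more than the scatter: a 2.3-fold higher number from compound 1 to compound 2 (0.37 log units; beyond the scatter). The other two steps stay within it: a 1.8-fold higher number from compound 1 to compound 3 (0.26 log units; within the scatter), and a 1.3-fold lower number from compound 2 to compound 3 (0.10 log units; within the scatter).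

Compound 4 `c1ccc(-c2nnc(SCCCN3CCN(c4nc5ccccc5o4)CC3)o2)cc1` differs from compound 1 in one place: hydrogen in place of methoxy on an aromatic carbon. Cut one bond further out, the same difference reads 4-methoxyphenyl to phenyl.

The step that bears on this change is the one that also removes the methoxy from compound 1, a 2.3-fold higher number from compound 1 to compound 2 (0.37 log units; beyond the scatter), a modest rise. The step of a 1.8-fold higher number from compound 1 to compound 3 (0.26 log units; within the scatter), which keeps the oxygen, shows no movement beyond the scatter. Nothing measured removes the group entirely. The expectation for compound 4 is therefore a small rise in the number, a 1.5-fold higher number from compound 1 to compound 4 (0.18 log units; within the scatter), or possibly none beyond the scatter. Compound 4 is estimated at 100000 nM, within a range from 40000 nM to 250000 nM.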

Compound 4, half-maximal inhibitory concentration: 102000 nM
Compound 4: middle estimate off by 1.0-fold (0.01 log units), on the low side, within the range that was stated.
By their numbers in this assay, from the lowest: compounds 1, 4, 3 and 2 (each within the scatter of the next, the first and the last beyond it).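

Taking the group away altogether, leaving only hydrogen on the aromatic carbon, gives a 1.5-fold higher number from compound 1 to compound 4 (0.19 log units; within the scatter) in this assay, so the methoxy of compound 1 cannot be told apart from no substituent at all. The unsubstituted phenyl also stays level with the other two groups, with a 1.2-fold lower number from compound 3 to compound 4 (0.07 log units; within the scatter) and a 1.5-fold lower number from compound 2 to compound 4 (0.18 log units; within the scatter) as the steps, which places compound 4 within the scatter of all three earlier compounds and shows that this position, with these four groups, yields only one separation, the one between methoxy and methyl. Nothing available gives a reason for these numbers.

The compounds shown leave open whether a group of another kind on this aromatic carbon, such as an amine, a carboxylic acid or a fluorine, would move the number beyond the scatter from the value of the unsubstituted compound 4. They also leave open whether the number responds more strongly to a change elsewhere on the shared core, for example a longer chain in place of the one that carries the sulfur.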